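A few compounds are considered here, and "the series" means these few. Any claim that something is new, unique, unknown or untested is made for them only; others in the source may bear on it.

Measured in a functional assay on B16 cells (Mus musculus) for antiproliferative activity, read by MTT assay, with a stated time of 24 h; a lower number here means a stronger inhibitor, a higher number a weaker inhibitor:
- compound 1 `C=CCOc1ccc2c(=O)c(-c3cc(OC)c(OC)cc3OC)coc2c1`: 5100 nM
- compound 2 `C#CCOc1ccc2c(=O)c(-c3cc(OC)c(OC)cc3OC)coc2c1`: 4500 nM
- compound 3 `COc1cc(OC)c(-c2coc3cc(OCC(=O)c4cccc(C(F)(F)F)c4)ccc3c2=O)cc1OC`: > 10000 nM, a limit and not a number

Compound 3 stands at the limit of > 10000 nM in this assay, at which 1 of the 3 values shown sits. Compound 4 `COc1cc(OC)c(-c2coc3cc(OCc4ccccc4F)ccc3c2=O)cc1OC` keeps the shared core and differs only on the saturated chain carbon bound to an oxygen on an aromatic ring: 2-fluorophenyl in place of (3-(trifluoromethyl)phenyl)carbonyl on a saturated chain carbon bound to an oxygen on an aromatic ring.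

Three measured steps at this same place bear on the change. Swapping one small group for another gave a 1.1-fold lower number from compound 1 to compound 2 (0.05 log units; within the scatter). Bringing in the group that compound 4 gives up gave an at least 1.9-fold higher number from compound 1 to compound 3 (0.29 log units; that floor lies within the scatter) and an at least 2.2-fold higher number from compound 2 to compound 3 (0.34 log units; beyond the scatter). Among the compounds with values here, no measured compound carries 2-fluorophenyl, so this comparison is only a rough guide.

With (3-(trifluoromethyl)phenyl)carbonyl gone, a return towards the level of compound 2 at 4500 nM is expected. The expected step is an at least 1.6-fold lower number from compound 3 to compound 4 (0.22 log units; that floor lies within the scatter) in this assay, a modest one towards a stronger inhibitor. For compound 4 the estimate is 6000 nM, with an expected range of 2000 nM to 12000 nM.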

Compound 4, half-maximal inhibitory concentration: 1610 nM
The estimate for compound 4 lay 3.7-fold (0.57 log units) above the measured number; measured number below the stated range.
By their numbers in this assay, from the lowest: compound 4; then compounds 2 and 1 (each within the scatter of the next). At a limit, above all of these: compound 3.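

In this assay, the saturated chain carbon bound to an oxygen on an aromatic ring can carry an aromatic ring and still gain over the small groups: 2-fluorophenyl gives a 2.8-fold lower number from compound 2 to compound 4 (0.45 log units; beyond the scatter) and a 3.2-fold lower number from compound 1 to compound 4 (0.50 log units; beyond the scatter). Compound 3 also carries a six-membered aromatic ring of carbon only, yet the change gives an at least 6.2-fold lower number from compound 3 to compound 4 (0.79 log units; beyond the scatter), so a ring at this place does not by itself weaken the compounds shown. That step is only a floor, as compound 3 stands at a limit and not at a number: the limit of > 10000 nM in this assay, at which 1 of the 4 values shown sits.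

On these data alone, the change removes the carbonyl and the trifluoromethyl and brings in the fluorine all at once, so the share of each stays unknown. As far as these compounds go, whether the fluorine is needed at all, and how a plain phenyl or a phenyl bearing an amine would behave, remains open.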